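Bis-acylisothioureas and isoselenoureas: methylsulfanyl to benzylselanyl

The compounds below may be only part of what the source reports. "The series", "measured", "known", "first", "only" and "open" are said of these compounds alone.

Measured so far:
compound 1 `CS/C(=N\C(=O)c1ccno1)NC(=O)c1ccno1`: 16900 nM
compound 2 `C[Se]/C(=N\C(=O)c1sccc1Cl)NC(=O)c1sccc1Cl`: 3160 nM
compound 3 `C[Se]/C(=N\C(=O)c1cnc2ccccc2c1)NC(=O)c1cnc2ccccc2c1`: 20300 nM

The read-out is an ADME assay on MCF-10A cells (Homo sapiens) for cytotoxicity, read by MTT assay, with a stated time of 72 h; on this read-out higher numbers stand for weaker inhibition of growth and lower numbers for stronger inhibition of growth. Compound 1 gives 16900 nM, the second highest of the three numbers. Compound 3 with 20300 nM lies within the scatter of compound 1, while compound 2 with 3160 nM gives a lower number, beyond the scatter. Compound 4 `O=C(/N=C(/NC(=O)c1ccno1)[Se]Cc1ccccc1)c1ccno1` has not been measured. It differs from compound 1 as follows: a group of 8 heavy atoms (7 carbon, 1 selenium; one six-membered aromatic ring of carbon only) in place of a group of 2 heavy atoms (1 carbon, 1 sulfur; no ring), on a carbon with a double bond to nitrogen. For the measured compounds named here, no two measured compounds differ in one place, so no measured step guides this change. In this assay a modest step toward a lower number is expected, perhaps not beyond the scatter. Compound 4 is estimated at 9000 nM, range 2500 nM to 30000 nM, which means an expected step of a 1.9-fold lower number from compound 1 to compound 4 (0.27 log units; within the scatter).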

Compound 4, concentration for 50% growth inhibition: 7800 nM
Compound 4: middle estimate off by 1.2-fold (0.06 log units), on the high side; the range from low to high includes it.
By their numbers in this assay, from the lowest: compound 2; then compound 4; then compounds 1 and 3 (each within the scatter of the next).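

For the compounds shown here, on the core of compound 1, the carbon with a double bond to nitrogen tolerates a larger group: a 2.2-fold lower number from compound 1 to compound 4 (0.34 log units; beyond the scatter) in this assay is the first single-place step. Replacing methylsulfanyl with a group carrying selenium and a six-membered aromatic ring gives a modest change, and growth inhibition is retained. No measurement available here accounts for this step.

Sulfur and selenium change together with the ring in this step, so their shares cannot be separated. A benzylsulfanyl or methylselanyl group on the core of compound 1 would separate them.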